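The source may report more compounds than this note shows. Statements on the series, on what has been measured and on what is new or still open speak of the compounds shown alone.

Working notes on the series. In an assay on isolated protein for inhibition of vitamin D3 receptor (Homo sapiens), read by fluorescence polarization (on this read-out lower numbers stand for stronger inhibition and higher numbers for weaker inhibition), compound 1 `CS(=O)(=O)c1ccc(C(=O)N2CCC(C(=O)N3CCN(c4ccc(F)cc4)CC3)CC2)cc1[N+](=O)[O-]` gives only the assay limit > 60000 nM. Compound 2 `CC(C)N(C(=O)CCNC(=O)c1ccc(S(C)(=O)=O)c([N+](=O)[O-])c1)C(C)C` likewise reaches only the limit > 60000 nM. Compound 3 `CS(=O)(=O)c1ccc(C(=O)NCCC(=O)N2CCc3ccccc32)cc1[N+](=O)[O-]` too stays at the limit > 60000 nM. All three values shown sit at the limit of > 60000 nM in this assay, at which 3 of the 3 values shown sit, so compound 3 stands level with the other two and nowhere readable on the numbers. Going by the values given here, the single step between measured compounds, a step that the two limits leave unreadable from compound 2 to compound 3, cannot be read either. Compound 4 `CS(=O)(=O)c1ccc(C(=O)NCCC(=O)N2CCCc3ccccc32)cc1[N+](=O)[O-]` differs from compound 3 by 1,2,3,4-tetrahydroquinolin-1-yl in place of 2,3-dihydro-1H-indol-1-yl on a carbonyl carbon. Among the compounds with values here, no measured step bears on this change, and with every value at the limit no direction is expected. The expectation is that compound 4 again shows no readable inhibition in this assay, so a step that the limit leaves unreadable from compound 3 to compound 4 is expected to stay unreadable. Compound 4 is therefore estimated at 80000 nM, between 30000 nM and 300000 nM.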

Compound 4, half-maximal inhibitory concentration: > 60000 nM
Compound 4 was reported as a limit; the forecaster's own chance of this, stated with the estimate: 90%; the middle value is on the limit's open side.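

Going by these compounds alone, compound 4 gives only the limit > 60000 nM and so no step from compound 2 or compound 3 to compound 4 can be read. The compounds shown leave open which structural change, if any, brings readable inhibition in this assay and what size any such step would have: the limit of > 60000 nM in this assay, at which 4 of the 4 values shown sit.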